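This account rests on a few compounds, and the source may have more. Where it says the series, first, only, none or still open, it means among the compounds named here.

Series notes, cytotoxicity. Compound 1 `CO/N=c1\[nH]cnc2c1[n+](C/C=C(\C)CC/C=C(\C)CC/C=C(\C)CCC=C(C)C)cn2C(c1ccccc1)c1ccccc1` gives 3540 nM in a functional assay on CEM/s cells (Homo sapiens) for cytotoxicity; on this read-out lower numbers stand for stronger inhibition and higher numbers for weaker inhibition. Compound 2 `CC(C)=CCC/C(C)=C/CC/C(C)=C/CC/C(C)=C/C[n+]1cn(C(c2ccccc2)c2ccccc2)c2nc[nH]/c(=N\OCc3ccccc3)c21` gives 9110 nM in this assay. The change between them, (phenyl in place of hydrogen on a saturated chain carbon bound to an oxygen), made a step of a 2.6-fold higher number from compound 1 to compound 2 (0.41 log units; beyond the scatter). Compound 3 `CO/N=c1\[nH]cnc2c1[n+](C/C=C(\C)CCCC(C)CCCC(C)CCCC(C)C)cn2C` gives 7920 nM in this assay; how its core differs from that of compound 1 is not broken down here, and its value against compound 2 falls within the scatter. Compound 4 `C/C(=C\C[n+]1cn(C)c2nc[nH]/c(=N\OCc3ccccc3)c21)CCCC(C)CCCC(C)CCCC(C)C` carries the same change relative to compound 3, namely (phenyl in place of hydrogen on a saturated chain carbon bound to an oxygen), at the same place. For the measured compounds named here, because the earlier step of a 2.6-fold higher number from compound 1 to compound 2 (0.41 log units; beyond the scatter) was modest but beyond the scatter, a step of similar size and direction is expected from compound 3 to compound 4, estimated as a 2.4-fold higher number from compound 3 to compound 4 (0.38 log units; beyond the scatter), this estimate resting on only that one precedent. Compound 4 is therefore expected to give about 19000 nM, estimated between 8000 nM and 45000 nM.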

Compound 4, half-maximal inhibitory concentration: 6300 nM
Beside the measured number, compound 4's estimate is 3.0-fold (0.48 log units) above it, outside the stated range (below it).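

In this assay the change from methoxy to benzyloxy gave a 1.3-fold lower number from compound 3 to compound 4 (0.10 log units; within the scatter), so the step seen on the core of compound 1 did not recur at that size on the core of compound 3. The two steps differ: the same change on two cores in this assay, a 2.6-fold higher number (0.41 log units; beyond the scatter) from compound 1 to compound 2 and a 1.3-fold lower number (0.10 log units; within the scatter) from compound 3 to compound 4, 3.2-fold (0.51 log units) apart, beyond the scatter of two such steps

This shows that the change does not carry over as a fixed increment between these two cores, but it does not show which difference between the cores accounts for this, and two pairs give no rule for any other core.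

Still open, on these data alone, is how a different group on the oxygen, such as ethyl or a longer chain ending in an amine, would behave on each core.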